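A Chloro Replacement in a Series Without Measurable Potency

The compounds below may be only part of what the source reports. "The series", "measured", "known", "first", "only" and "open" are said of these compounds alone.

Of the compounds shown here, three of one family have so far been tested in a functional assay on Huh-7 cells (Homo sapiens) for inhibition, read by MTT assay, with a stated time of 48 h; a lower number here means a stronger inhibitor, a higher number a weaker inhibitor. Compound 1 (`Cc1nnsc1CO/N=C/c1c(C)nn(C)c1Oc1ccc(F)cc1`) gives > 50000 nM in this assay, which is a limit of the assay rather than a number. Compound 2 (`CCc1nnsc1CO/N=C/c1c(C)nn(C)c1Oc1ccc(C)cc1`) gives > 50000 nM, again a limit. Compound 3 (`CCCc1nnsc1CO/N=C/c1c(C)nn(C)c1Oc1ccc(F)cc1`) gives > 50000 nM, also a limit. Within the data shown here, the one step between compounds that differ in a single place, a step that the two limits leave unreadable from compound 1 to compound 3, is therefore unreadable. All three values sit at the limit of > 50000 nM in this assay, at which 3 of the 3 values shown sit, so compound 3 stands exactly where its two companions stand: at the limit, with no number of its own and no ordering possible among the three.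

Compound 4 (`CCCc1nnsc1CO/N=C/c1c(C)nn(C)c1Cl`) differs from compound 3 in one place: chloro in place of 4-fluorophenoxy on an aromatic carbon. Among the measured compounds shown here, no measured step bears on this exchange; the single step on record concerns another position and is itself unreadable. The data give no ground to expect a shift of any particular size or direction in this assay, and with every neighbour at the limit the most probable outcome is that compound 4 also returns a limit. Compound 4 is accordingly expected to give about 50000 nM, with a range from 20000 nM to 200000 nM. That expectation corresponds to a number no higher from compound 3 to compound 4 (the limit leaves the size open), no movement beyond the scatter.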

Compound 4, half-maximal inhibitory concentration: > 50000 nM
Compound 4: a limit, no number; the forecaster's own chance of this, stated with the estimate: 85%; the middle value sits exactly at the limit.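

In this assay compound 4 gives > 50000 nM, which is a limit of the assay and not a number. Compound 3 also stands at a limit, so no step can be read between compound 3 and compound 4: the limit of > 50000 nM in this assay, at which 4 of the 4 values shown sit. The compounds shown leave open whether any member of this family gives a measurable number in this assay.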